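Difluorophenyl swap in a series sitting at the limit

The source may report more compounds than this note shows. Statements on the series, on what has been measured and on what is new or still open speak of the compounds shown alone.

In a toxicity assay on Vero cells (Chlorocebus sabaeus) for cytotoxicity (a lower number here means that less compound is tolerated, a higher number that more compound is tolerated), compound 1 `COc1ncc(-c2ccccc2)cc1[C@@H](c1ccccc1)[C@@](O)(CCN(C)C)c1cc(F)ccc1F` gives > 50 ug/mL, a limit and not a number. Compound 2 `COc1nc(-c2ccc(F)cc2)ccc1[C@@H](c1ccccc1)[C@@](O)(CCN(C)C)c1cccc2ccccc12` gives > 50 ug/mL, also a limit. Compound 3 `COc1nc(-c2ccc(C(F)(F)F)cc2)ccc1[C@@H](c1ccccc1)[C@@](O)(CCN(C)C)c1cccc2ccccc12` gives > 50 ug/mL, again a limit. Among the compounds with values here, the series so far shows (the limit of > 50 ug/mL in this assay, at which 3 of the 3 values shown sit). Within the data shown here, the one measured step, a step that the two limits leave unreadable from compound 2 to compound 3, has no readable size and does not involve the group changed here. Compound 4 `COc1ncc(-c2ccccc2)cc1[C@@H](c1ccccc1)[C@@](O)(CCN(C)C)c1cccc(F)c1F` carries 2,3-difluorophenyl in place of 2,5-difluorophenyl on a saturated chain carbon bound to an oxygen on a saturated carbon and two saturated chain carbons. The expected change in this assay is a step that the limit leaves unreadable from compound 1 to compound 4, with no step beyond the scatter and no direction expected. For compound 4 the estimate is 60 ug/mL, with an expected range of 35 ug/mL to 100 ug/mL.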

Compound 4, half-maximal cytotoxic concentration: > 50 ug/mL
Compound 4: only a limit was reported; the forecaster's own chance of this, stated with the estimate: 80%; the middle value is on the limit's open side.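

Within the data shown here, compound 1 and compound 4 are both reported only as limits, so no step between them can be read. The compounds shown leave open whether 2,3-difluorophenyl and 2,5-difluorophenyl differ at all in the concentration tolerated: the limit of > 50 ug/mL in this assay, at which 4 of the 4 values shown sit.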